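Ester to primary amide on the shared core

The source may report more compounds than this note shows. Statements on the series, on what has been measured and on what is new or still open speak of the compounds shown alone.

Measured compounds:
compound 1 `COC(=O)c1ccc2ccc(C(=O)c3ccccc3)c-2cc1` — 28.9%
compound 2 `COC(=O)c1ccc2ccc(C(=O)c3ccc(C(F)(F)F)cc3)c-2cc1` — -47.4%
compound 3 `O=C(O)c1ccc2ccc(C(=O)c3ccc(C(F)(F)F)cc3)c-2cc1` — 1%

In an assay on cells for displacement of a labelled ligand from Orexin receptor type 2 (Homo sapiens), read by scintillation counting, with stated times of 10 min and 90 min, tested at 10 uM (on this read-out higher numbers stand for more inhibition at the one concentration tested (going by the name of the read-out) and lower numbers for less inhibition), compound 1 gives 28.9%, the highest of the three numbers. Compound 3 gives 1% and compound 2 gives -47.4%; both fall well short of compound 1. Two single-change steps are available. Trifluoromethyl in place of hydrogen on an aromatic carbon gives a number 76.3 percentage points lower from compound 1 to compound 2 (beyond the scatter). Hydrogen in place of methyl on an oxygen next to a carbonyl group gives a number 48.4 percentage points higher from compound 2 to compound 3 (beyond the scatter).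

Compound 4 `NC(=O)c1ccc2ccc(C(=O)c3ccccc3)c-2cc1` is not yet measured. Its change from compound 1 is amino in place of methoxy on a carbonyl carbon. Among the compounds with values here, no measured step exchanges methoxy for amino on this carbonyl carbon. The step from compound 2 to compound 3 touches the same methoxycarbonyl group, converting it to an acid rather than an amide, and it was large and upward; but it was read on the trifluoromethyl-bearing pair, and nothing shows how the unsubstituted benzoyl series responds to a change at this group. The expectation is therefore a step of modest size from compound 1 to compound 4 in this assay, with the direction open, estimated as a number 8.9 percentage points lower from compound 1 to compound 4 (within the scatter). Compound 4 is expected to give 20%, within a range from -20% to 55%.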

Compound 4, a percentage reported as inhibition, at one concentration (the size of the read-out at that concentration, not a potency): 18%
For compound 4 the middle estimate is 2 percentage points above the measured one; measured number inside the range.
By their numbers in this assay, from the lowest: compound 2; then compound 3; then compound 4; then compound 1.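

In this assay, within the data shown here, amino in place of methoxy on a carbonyl carbon gives a number 10.9 percentage points lower from compound 1 to compound 4 (beyond the scatter), the first reading of any change at this group without trifluoromethyl. The step is modest, and compound 4 stays on the positive side at 18%, so on this core the methoxycarbonyl group can be exchanged for carbamoyl at the cost of only part of the inhibition seen at the one concentration tested. Among these compounds, the only other step at this group, a number 48.4 percentage points higher from compound 2 to compound 3 (beyond the scatter), is a different exchange on a different pair and runs the other way, so the two steps give no common rule for the position, and no available data bear on the reason for the drop.

Still open, from the compounds shown here alone, is how a carboxylic acid on this carbonyl carbon reads on the core of compound 1, and how carbamoyl reads with trifluoromethyl present, which together would show whether the two changes depend on each other. Also open, going by these compounds, is whether methylamino or dimethylamino in place of amino holds the number of compound 4 or moves it further.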